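The compounds below may be only part of what the source reports. "The series", "measured", "known", "first", "only" and "open" are said of these compounds alone.

Measured compounds:
compound 1, `Cc1nc(N2CCN(C3CCCC3)CC2)nc2ccc(NC(=O)COc3ccc(Cl)cc3)cc12` — a functional assay on CHO-K1 cells for antagonist activity at melanin-concentrating hormone receptor 1 (Homo sapiens), read by inositol phosphate accumulation; a lower number here means a stronger inhibitor, a higher number a weaker inhibitor: compound 1 gives 150 nM
compound 2, `Cc1nc(N2CCN(C)CC2)nc2ccc(NC(=O)COc3ccc(Cl)cc3)cc12` — in this assay compound 2 gives 3800 nM

Among the compounds with values here, compound 2 stands at the highest of the two numbers in this assay; its nearest neighbour, compound 1, sits well below it, the only measured step in this pair of compounds being a 25-fold higher number from compound 1 to compound 2 (1.40 log units; beyond the scatter), with methyl in place of cyclopentyl on the amine nitrogen of the ring.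

The next compound, compound 3, `Cc1nc(N2CCN(CC(C)(C)C)CC2)nc2ccc(NC(=O)COc3ccc(Cl)cc3)cc12`, has not been measured. It differs from compound 2 by tert-butyl in place of hydrogen on a saturated chain carbon bound to an amine nitrogen in a ring; cut one bond further out, this reads methyl to neopentyl, or 4-methylpiperazin-1-yl to 4-neopentylpiperazin-1-yl.

Within the data shown here, the one step that bears on it is a 25-fold higher number from compound 1 to compound 2 (1.40 log units; beyond the scatter): it shows that the group on this amine nitrogen moves the number in this assay strongly, methyl being far weaker than cyclopentyl. Neopentyl is not cyclopentyl, so a full return to the level of compound 1 is not assumed, but a clear drop beyond the scatter is expected for compound 3, the estimated step being an 8.4-fold lower number from compound 2 to compound 3 (0.93 log units; beyond the scatter). Compound 3 is therefore expected to give about 450 nM in this assay, estimated within 120 nM to 1700 nM.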

Compound 3, half-maximal inhibitory concentration: 246 nM
The estimate for compound 3 lay 1.8-fold (0.26 log units) above the measured number; low and high end bracket the measured number.
By their numbers in this assay, from the lowest: compounds 1 and 3 (each within the scatter of the next); then compound 2.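

In this assay, the step of a 15-fold lower number from compound 2 to compound 3 (1.19 log units; beyond the scatter) shows that the substituent on this amine nitrogen need not contain a ring for the number to fall well below that of the methyl compound, since neopentyl, an open-chain group, is enough. The step of a 1.6-fold higher number from compound 1 to compound 3 (0.21 log units; within the scatter) lies within the scatter, so this assay does not separate neopentyl from cyclopentyl, and across these three compounds only methyl stands apart from the other two groups. Nothing available gives a reason for this behaviour at the position, so the numbers stand as a description only.

The compounds shown do not tell whether the number falls gradually or abruptly from methyl to neopentyl, which ethyl, isopropyl or an unbranched propyl chain on the same nitrogen could help to settle. They also leave open whether the level shared by compound 1 and compound 3 can be passed, or is lost, with a longer chain, a benzyl group, or a chain ending in a hydroxyl group or a carboxylic acid.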